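This account rests on a few compounds, and the source may have more. Where it says the series, first, only, none or still open, it means among the compounds named here.

For the measured compounds named here, compound 2, `CCN(CC)S(=O)(=O)c1ccc(S(=O)(=O)N2CCC[C@@H](C(=O)N3CCC(COC)CC3)C2)cc1`, gives 1360 nM in a functional assay on BXPC-3 cells (Homo sapiens) for inhibition, read by MTT assay, with a stated time of 7 days (a higher number here means a weaker inhibitor, a lower number a stronger inhibitor), the higher of the two numbers measured so far. Compound 1, `CCN(CC)S(=O)(=O)c1ccc(S(=O)(=O)N2CCC[C@@H](C(=O)N3CCC(C(F)(F)F)CC3)C2)cc1`, differs from it only in the group on the saturated ring carbon and gives 370 nM. Going by the values given here, the one measured step that bears on the question is a 3.7-fold higher number from compound 1 to compound 2 (0.57 log units; beyond the scatter). Compound 3, `CCN(CC)S(=O)(=O)c1ccc(S(=O)(=O)N2CCC[C@@H](C(=O)N3CCC(C(F)F)CC3)C2)cc1`, has not yet been measured; it carries difluoromethyl in place of methoxymethyl on a saturated ring carbon. Difluoromethyl stands nearer to trifluoromethyl than methoxymethyl does, so the change is expected to undo part of that measured step, giving compound 3 a lower number than compound 2. Among the compounds with values here, it may not return the whole way to compound 1, because a 3.7-fold higher number from compound 1 to compound 2 (0.57 log units; beyond the scatter) involved a full trifluoromethyl group and no difluoromethyl compound has been measured here. The expected step is therefore a 2.5-fold lower number from compound 2 to compound 3 (0.39 log units; beyond the scatter). Compound 3 is estimated at 550 nM, with a likely range from 250 nM to 1200 nM.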

Compound 3, half-maximal inhibitory concentration: 450 nM
Beside the measured number, compound 3's estimate is 1.2-fold (0.09 log units) above it; low and high end bracket the measured number.
By their numbers in this assay, from the lowest: compounds 1 and 3 (each within the scatter of the next); then compound 2.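

In this assay, difluoromethyl in place of methoxymethyl on this saturated ring carbon gives a 3.0-fold lower number from compound 2 to compound 3 (0.48 log units; beyond the scatter) and so brings the number back into the range of the trifluoromethyl compound. Hydrogen in place of one fluoro on that group gives a 1.2-fold higher number from compound 1 to compound 3 (0.09 log units; within the scatter) and so leaves the two fluorinated groups indistinguishable here, while methoxymethyl stands apart from both. Nothing measured here explains why the fluorinated groups and methoxymethyl differ.

Going by these compounds, it remains open whether a plain methyl, a hydroxymethyl or an amine on this carbon would fall with the two fluorinated groups or with methoxymethyl. On these data alone, it is also open whether a longer chain carrying the same ether oxygen would track methoxymethyl in this assay.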